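The source may report more compounds than this note shows. Statements on the series, on what has been measured and on what is new or still open speak of the compounds shown alone.

Compound 1 `C#CCOc1ccc(/C=C/C(=O)c2cccc(Br)c2)cc1OC` gives 3500 nM in a functional assay on MDA-MB-231 cells (Homo sapiens) for cytotoxicity, with a stated time of 72 h (on this read-out lower numbers stand for stronger inhibition and higher numbers for weaker inhibition), the lower of the two numbers recorded so far; compound 2 `C=CCOc1ccc(C=O)cc1OC` gives 15000 nM in this assay, a gap that lies beyond the usual scatter. Compound 3 `C#CCOc1ccc(/C=C/C(=O)c2ccccc2C)cc1OC` is not yet measured. It differs from compound 1 by 2-methylphenyl in place of 3-bromophenyl on a carbonyl carbon. Going by the values given here, no step between measured compounds bears on this change, so its direction is open; a step within the scatter, or at most a modest weakening, is expected. For compound 3 in this assay the estimate is 4500 nM, with a range from 1500 nM to 14000 nM. That corresponds to an expected step of a 1.3-fold higher number from compound 1 to compound 3 (0.11 log units; within the scatter).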

Compound 3, half-maximal inhibitory concentration: 14800 nM
Compound 3: middle estimate off by 3.3-fold (0.52 log units), on the low side; measured number outside the range, above it.
By their numbers in this assay, from the lowest: compound 1; then compounds 3 and 2 (each within the scatter of the next).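

In this assay, the aryl group on the carbonyl carbon proves to matter: 2-methylphenyl in place of 3-bromophenyl gives a 4.2-fold higher number from compound 1 to compound 3 (0.63 log units; beyond the scatter) as a modest weakening. Both groups have the same heavy-atom count and neither has hydrogen-bond donors or acceptors, so those counts do not separate them. No available measurement accounts for this step. Still open, going by these compounds, is whether the step follows from losing bromine or from where the substituent sits, and how an aminophenyl or carboxyphenyl group would behave on this carbonyl carbon. A single step gives no trend for this position.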